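A few compounds are considered here, and "the series" means these few. Any claim that something is new, unique, unknown or untested is made for them only; others in the source may bear on it.

Measured so far:
compound 1, `Nc1ncnc2c1ncn2[C@@H]1O[C@H](COC(=O)c2cc[nH]c2)[C@@H](O)[C@H]1O`: 87%
compound 2, `Nc1nc2c(ncn2[C@@H]2O[C@H](COC(=O)c3cc[nH]c3)[C@@H](O)[C@H]2O)c(=O)[nH]1`: 82%

In an assay for inhibition of MAP kinase-activated protein kinase 2 (Homo sapiens), read by Z'-LYTE, with a stated time of 1 h, tested at 10 uM (a higher number here means more inhibition at the concentration tested (going by the name of the read-out), a lower number less inhibition), compound 1 gives 87% and compound 2 gives 82%. Compound 2 has the lower of the two numbers, yet the gap to compound 1 lies within the scatter, so nothing separates them. Compound 3, `O=C(OC[C@H]1O[C@@H](n2cnc3c(=O)[nH]cnc32)[C@H](O)[C@@H]1O)c1cc[nH]c1`, has not been measured. It differs from compound 2 by hydrogen in place of amino on an aromatic carbon. Going by the values given here, with no measured step of this kind available, the step from compound 2 to compound 3 is expected to be a modest loss in this assay, a number 12 percentage points lower from compound 2 to compound 3 (beyond the scatter), somewhat beyond the scatter. Compound 3 is therefore estimated at 70%, with a range from 45% to 90%.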

Compound 3, a percentage reported as inhibition, at one concentration (the size of the read-out at that concentration, not a potency): 89%
Beside the measured number, compound 3's estimate is 19 percentage points below it, and the stated range covers the measured number.
By their numbers in this assay, from the lowest: compounds 2, 1 and 3 (each within the scatter of the next).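

In this assay, hydrogen in place of amino on the aromatic carbon between two ring nitrogen atoms gives a number 7 percentage points higher from compound 2 to compound 3 (within the scatter) and so leaves compound 2 and compound 3 unseparated. This single step shows that, at the concentration tested, the read-out does not depend measurably on the amino group at this position. Nothing available explains this result.

From the compounds shown here alone, with a reading at one concentration, any difference in potency between the two compounds remains open. So does the effect of a methyl group, a chlorine atom or a dimethylamino group on this carbon.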